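Swapping a Hydroxyphenyl for a Chlorophenyl: Expected Cytotoxicity

The compounds below may be only part of what the source reports. "The series", "measured", "known", "first", "only" and "open" are said of these compounds alone.

Compound 1 `O=S(=O)(Nc1ccc(-c2nc3ccccc3o2)cc1)c1cccc(O)c1` was examined in an ADME assay on HEK293 cells (Homo sapiens) for cytotoxicity, read by resazurin assay, with a stated time of 48 h; on this read-out lower numbers stand for higher toxicity in this test and higher numbers for lower toxicity in this test. In this assay compound 1 gives > 100000 nM, which is a limit of the assay rather than a measured number. Compound 1 therefore sits at the limit of > 100000 nM in this assay, at which 1 of the 2 values shown sits. A second compound, compound 2 `O=S(=O)(Nc1ccc2oc(-c3ccccc3)nc2c1)c1ccccc1O`, carries a related sulfonamide; in this assay compound 2 gives 33000 nM. Among the measured compounds shown here, no single-point step between these two compounds is recorded, so only their two values can be placed side by side.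

The unmeasured compound 3 `O=S(=O)(Nc1ccc(-c2nc3ccccc3o2)cc1)c1ccc(Cl)cc1` differs from compound 1 in one place: 4-chlorophenyl in place of 3-hydroxyphenyl on a sulfonyl sulfur. No measured step of this kind exists among the compounds shown, so the size of the change in this assay is open; a shift within the usual scatter, or a modest move toward higher toxicity, is expected. For compound 3 the estimated value in this assay is 70000 nM, with a range from 25000 nM to 150000 nM. This amounts to an expected step of an at least 1.4-fold lower number from compound 1 to compound 3 (0.15 log units; that floor lies within the scatter).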

Compound 3, half-maximal cytotoxic concentration: > 100000 nM
Compound 3: only a limit was reported; the forecaster's own chance of this, stated with the estimate: 45%; middle value at least 1.4-fold (0.15 log units) away from the limit.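

In this assay compound 3 gives > 100000 nM as a limit of the assay. Compound 1 stands at the same limit, so no step can be read between compound 1 and compound 3: the limit of > 100000 nM in this assay, at which 2 of the 3 values shown sit. On these data alone, how far 4-chlorophenyl in place of 3-hydroxyphenyl moves the true value stays open.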